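Isatin-type series: benzyl replacement on the ring nitrogen

The compounds below may be only part of what the source reports. "The series", "measured", "known", "first", "only" and "open" are said of these compounds alone.

Three compounds carry numbers in a functional assay on K562 cells (Homo sapiens) for cytotoxicity, read by MTT assay, with a stated time of 48 h; on this read-out lower numbers stand for stronger inhibition and higher numbers for weaker inhibition. Compound 3 `COC(=O)/C=C/c1ccc2c(c1)C(=O)C(=O)N2Cc1cc(C)cc(C)c1` gives 40 nM in this assay. Compound 1 `COc1ccc(CN2C(=O)C(=O)c3cc(/C=C/C(=O)OC(C)(C)C)ccc32)cc1` gives 50 nM in this assay, a number within the scatter of compound 3, so the two cannot be put in order. Compound 2 `COC(=O)/C=C/c1cccc2c1N(Cc1ccc(OC)cc1)C(=O)C2=O`, in which the acrylate chain sits on the other side of the core, gives 4130 nM in this assay, a number far higher than that of compound 3 and well beyond the scatter. Compound 3 therefore stands at the low end of the three numbers, with compound 1 beside it and compound 2 apart.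

Compound 4 `COC(=O)/C=C/c1ccc2c(c1)C(=O)C(=O)N2Cc1ccc(C#N)cc1` has not been measured in this assay. It differs from compound 3 in one place: 4-cyanophenyl in place of 3,5-dimethylphenyl on a saturated chain carbon bound to an amide-type nitrogen in a ring. Within the data shown here, no measured pair in the set reports this kind of change, so the size of the step is not known from the data. Since both compound 3 and compound 1 keep low numbers with different benzyl groups, a small step is expected, possibly toward a somewhat higher number, but not clearly beyond the scatter. The expected step of a 2.3-fold higher number from compound 3 to compound 4 (0.35 log units; beyond the scatter) reflects this. Compound 4 is estimated at 90 nM in this assay, with a range from 25 nM to 350 nM.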

Compound 4, half-maximal inhibitory concentration: 30 nM
Compound 4: middle estimate off by 3.0-fold (0.48 log units), on the high side; the measured number falls inside the stated range.
By their numbers in this assay, from the lowest: compounds 4, 3 and 1 (each within the scatter of the next); then compound 2.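

In this assay, the swap on a saturated chain carbon bound to an amide-type nitrogen in a ring gives a 1.3-fold lower number from compound 3 to compound 4 (0.12 log units; within the scatter), so 4-cyanophenyl and 3,5-dimethylphenyl cannot be put in order at this place. Among these compounds, this single-place pair is the first direct reading of the position: two methyl groups leave, a nitrile enters with one hydrogen-bond acceptor where the leaving group has none, and the number stays within the scatter. Nothing at hand bears on why the two groups give such close numbers.

From the compounds shown here alone, one pair with two aryl groups does not define the scope of the position, so it remains open whether the numbers hold with an aminomethyl group or a carboxylic acid on the phenyl ring, or with a longer chain in place of the saturated chain carbon. Also open, going by these compounds, is whether the same swap would read alike with the acrylate chain placed as in compound 2, whose number stands far from the others, or with the tert-butyl ester of compound 1.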